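From a Difluorophenyl Arm to a Sulfonamide Arm

This account rests on a few compounds, and the source may have more. Where it says the series, first, only, none or still open, it means among the compounds named here.

Compound 1, `O=C1O[C@H]([C@@H](O)Cn2cc(-c3cc(F)cc(F)c3)nn2)C(OCc2ccccc2)=C1OCc1ccccc1`: > 100000 nM
Compound 2, `O=C1O/C(=C\Cn2cc(-c3cccc(O)c3)nn2)C(OCc2ccccc2)=C1OCc1ccccc1`: 42600 nM
Compound 3, `O=C1O/C(=C\Cn2cc(-c3cc(C(F)(F)F)cc(C(F)(F)F)c3)nn2)C(OCc2ccccc2)=C1OCc1ccccc1`: > 100000 nM

Of the compounds shown here, three built on one shared core have been tested in an ADME assay on HFF cells (Homo sapiens) for cytotoxicity, read by MTT assay, with a stated time of 72 h; a lower number here means a stronger inhibitor, a higher number a weaker inhibitor. In this assay compound 1 gives > 100000 nM, which is a limit of the assay and not a number. Compound 3 gives > 100000 nM, also a limit. Going by the values given here, compound 2 is the one with a number, 42600 nM. Compound 1 thus stands at the limit of > 100000 nM in this assay, at which 2 of the 3 values shown sit, and the two values at that limit cannot be ordered against each other.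

Compound 4, `O=C1O[C@H]([C@@H](O)Cn2cc(CNS(=O)(=O)c3ccc(Cl)cc3)nn2)C(OCc2ccccc2)=C1OCc1ccccc1`, is the next candidate for this assay. It differs from compound 1 in one place: (((4-chlorophenyl)sulfonyl)amino)methyl in place of 3,5-difluorophenyl on an aromatic carbon. Among the compounds with values here, no pair of measured compounds shows this kind of change, so no measured step gives its size. With compound 1 sitting at a limit, the expected step from compound 1 to compound 4 is small and most likely none beyond the scatter, with a modest chance that compound 4 falls to a measurable number. Compound 4 is therefore estimated at 80000 nM, with a range from 30000 nM to 150000 nM, which corresponds to an expected step of an at least 1.2-fold lower number from compound 1 to compound 4 (0.09 log units; that floor lies within the scatter).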

Compound 4, half-maximal inhibitory concentration: 20 nM
Estimate against measurement, compound 4: 4000-fold (3.60 log units) above, and the stated range ends above it.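

In this assay, the aromatic carbon of the five-membered aromatic ring with 3 nitrogen proves to be a place where one exchange can move the read-out a very long way: (((4-chlorophenyl)sulfonyl)amino)methyl in place of 3,5-difluorophenyl gives an at least 5000-fold lower number from compound 1 to compound 4 (3.69 log units; beyond the scatter). Going by these compounds alone, the earlier compounds offered no measured step at all, so this is the only change in the set whose effect can be read, and it shows that the group on this carbon alone can carry a large difference in this assay. The step is a floor and not an exact size, and compound 1 stands at a limit of the assay and not at a number: the limit of > 100000 nM in this assay, at which 2 of the 4 values shown sit.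

The compounds shown leave open which part of the new group accounts for the step, as the sulfonyl, the amino hydrogen, the methyl link and the chlorine all enter together. Also open, as far as these compounds go, is whether a simple amine or a carboxylic acid on the same carbon would give a low number as well, and whether the same group would do so on the core of compound 2.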